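The source may report more compounds than this note shows. Statements on the series, on what has been measured and on what is new or still open speak of the compounds shown alone.

Series notes. Compound 2 `Cc1cc(C)cc(S(=O)(=O)c2c(C(=O)NCC(=O)NCc3ccccc3F)[nH]c3ccc(Cl)cc23)c1` carries a 2-fluorobenzyl on the outer amide nitrogen. In an ADME assay on MT4 cells (Homo sapiens) for cytotoxicity, read by MTT assay (a higher number here means that more compound is tolerated, a lower number that less compound is tolerated), compound 2 gives only a limit, > 47300 nM. Compound 1 `Cc1cc(C)cc(S(=O)(=O)c2c(C(=O)NCC(=O)NC(C)c3ccncc3)[nH]c3ccc(Cl)cc23)c1` differs by 1-(pyridin-4-yl)ethyl in place of 2-fluorobenzyl on an amide-type nitrogen; in this assay compound 1 gives 47000 nM, and the step of a number no higher from compound 2 to compound 1 (the limit leaves the size open) cannot be sized since compound 2 sits at the limit of > 47300 nM in this assay, at which 1 of the 3 values shown sits. Compound 3 `Cc1cc(C)cc(S(=O)(=O)c2c(C(=O)NC(C)C(=O)NCc3ccccc3F)[nH]c3ccc(Cl)cc23)c1` bears a methyl on the chain; in this assay compound 3 gives 23300 nM, the step being an at least 2.0-fold lower number from compound 2 to compound 3 (0.30 log units; that floor lies within the scatter). Compound 4 `Cc1cc(C)cc(S(=O)(=O)c2c(C(=O)NC(C)C(=O)NC(C)c3ccncc3)[nH]c3ccc(Cl)cc23)c1` is not yet measured; it differs from compound 3 by 1-(pyridin-4-yl)ethyl in place of 2-fluorobenzyl on an amide-type nitrogen, the same change as that from compound 2 to compound 1, at the same place, while the cores of compound 3 and compound 2 differ by methyl in place of hydrogen on a saturated chain carbon bound to an amide-type nitrogen and a carbonyl carbon. The earlier step of a number no higher from compound 2 to compound 1 (the limit leaves the size open) was left open by the limit of compound 2, so for compound 4 the expected step is a 1.1-fold lower number from compound 3 to compound 4 (0.02 log units; within the scatter), a change within the scatter, resting on that earlier step. Compound 4 is thus estimated at 22000 nM, between 10000 nM and 47000 nM.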

Compound 4, half-maximal cytotoxic concentration: 21900 nM
The estimate for compound 4 lay 1.0-fold (0.00 log units) above the measured number; low and high end bracket the measured number.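

Series notes, continued. In this assay, methyl in place of hydrogen on the saturated chain carbon, now on the core carrying 1-(pyridin-4-yl)ethyl, gives a 2.1-fold lower number from compound 1 to compound 4 (0.33 log units; beyond the scatter), a modest step that can be set beside its counterpart on the 2-fluorobenzyl core only through a floor: the same change on two cores in this assay, an at least 2.0-fold lower number (0.30 log units; that floor lies within the scatter) from compound 2 to compound 3 and a 2.1-fold lower number (0.33 log units; beyond the scatter) from compound 1 to compound 4; the limit leaves it open whether they differ
1-(pyridin-4-yl)ethyl in place of 2-fluorobenzyl on the amide-type nitrogen gives a 1.1-fold lower number from compound 3 to compound 4 (0.03 log units; within the scatter), and its counterpart on the other core cannot be sized: the same change on two cores in this assay, a number no higher (the limit leaves the size open) from compound 2 to compound 1 and a 1.1-fold lower number (0.03 log units; within the scatter) from compound 3 to compound 4; the limit leaves it open whether they differ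
Compound 2 gives only a limit, > 47300 nM, so the steps from it cannot be read in full, and the four compounds show neither that these changes carry over between cores with the same size nor that they do not.

Open, from the compounds shown here alone, is whether an ethyl or a longer chain in place of the methyl on the saturated chain carbon would continue the step seen with methyl in this assay. Also open, going by these compounds, is how an amine or a carboxylic acid on the group at the amide-type nitrogen would read there.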